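Chloro to fluoro on compound 1: expectation for compound 4

The source may report more compounds than this note shows. Statements on the series, on what has been measured and on what is new or still open speak of the compounds shown alone.

Compound 1 `Cc1cc(Cl)ccc1Nc1ncc(C(F)(F)F)c(N2Cc3cccc(N(C)S(C)(=O)=O)c3C2)n1` gives the highest number of the three measured in a functional assay on HeLa cells (Homo sapiens) for antiproliferative activity, read by spectrophotometry, with a stated time of 2 days (on this read-out higher numbers stand for weaker inhibition of growth and lower numbers for stronger inhibition of growth), at 17400 nM. Compound 2 `CN(c1cccc2c1CN(c1nc(Nc3ccc(Cl)c(C(F)(F)F)c3)ncc1C(F)(F)F)C2)S(C)(=O)=O` gives 11100 nM; the step of a 1.6-fold lower number from compound 1 to compound 2 (0.20 log units; within the scatter) lies within the scatter. Compound 3 `CN(c1cccc2c1CN(c1nc(Nc3cccc(C(F)(F)F)c3)ncc1C(F)(F)F)C2)S(C)(=O)=O` gives 5300 nM and is furthest off, with a 3.3-fold lower number from compound 1 to compound 3 (0.52 log units; beyond the scatter). Compound 4 `Cc1cc(F)ccc1Nc1ncc(C(F)(F)F)c(N2Cc3cccc(N(C)S(C)(=O)=O)c3C2)n1` differs from compound 1 by fluoro in place of chloro on an aromatic carbon. Among the compounds with values here, no measured step exchanges chloro for fluoro; the nearest precedent is a 2.1-fold lower number from compound 2 to compound 3 (0.32 log units; beyond the scatter), a modest move, but on a differently substituted phenyl, so it bears only loosely here. A change no larger than that, and plausibly none beyond the scatter, is expected for a 1.2-fold lower number from compound 1 to compound 4 (0.09 log units; within the scatter). Compound 4 is estimated in this assay at 14000 nM, with a range from 7000 nM to 30000 nM.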

Compound 4, concentration for 50% growth inhibition: 6500 nM
Beside the measured number, compound 4's estimate is 2.2-fold (0.33 log units) above it, and the stated range ends above it.
By their numbers in this assay, from the lowest: compounds 3, 4, 2 and 1 (each within the scatter of the next, the first and the last beyond it).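

At the aromatic carbon para to a large group, fluoro in place of chloro gives a 2.7-fold lower number from compound 1 to compound 4 (0.43 log units; beyond the scatter) in this assay as a single-atom exchange, so this position is not indifferent to the halogen. The steps of a 1.2-fold higher number from compound 3 to compound 4 (0.09 log units; within the scatter) and a 1.7-fold lower number from compound 2 to compound 4 (0.23 log units; within the scatter) both stay within the scatter, so compound 4 sits level with both trifluoromethyl-bearing compounds. No measurement shown accounts for the halogen step.

Open, going by these compounds, is whether methoxy or nitrile at this carbon would follow fluoro or chloro, and whether the same exchange carries over to other aryl groups.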